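Dichlorophenyl Amide Estimated from Three Measured Analogues

The source may report more compounds than this note shows. Statements on the series, on what has been measured and on what is new or still open speak of the compounds shown alone.

Three compounds have been measured in a functional assay on MCF7 cells (Homo sapiens) for antiproliferative activity, read by MTT assay, with a stated time of 72 h; a higher number here means a weaker inhibitor, a lower number a stronger inhibitor:

Compound 1 `CCN1CCN(c2cc(C)c3cc(NC(=O)c4ccc(F)cc4)ccc3n2)CC1`: 4030 nM
Compound 2 `CCN1CCN(c2cc(C)c3cc(NC(=O)c4ccccc4F)ccc3n2)CC1`: 32600 nM
Compound 3 `CCN1CCN(c2cc(C)c3cc(NC(=O)c4ccccc4OC)ccc3n2)CC1`: 13200 nM

Compound 2 gives the highest number of the three; the closest gap is a 2.5-fold lower number from compound 2 to compound 3 (0.39 log units; beyond the scatter), the widest is an 8.1-fold higher number from compound 1 to compound 2 (0.91 log units; beyond the scatter). Compound 4 `CCN1CCN(c2cc(C)c3cc(NC(=O)c4ccc(Cl)c(Cl)c4)ccc3n2)CC1` has not been measured. Its change from compound 2 is 3,4-dichlorophenyl in place of 2-fluorophenyl on a carbonyl carbon. Going by the values given here, two measured steps bear on this: an 8.1-fold higher number from compound 1 to compound 2 (0.91 log units; beyond the scatter) shows that a 4-fluorophenyl compound sits far below the 2-fluorophenyl one, and a 2.5-fold lower number from compound 2 to compound 3 (0.39 log units; beyond the scatter) shows that replacing the 2-fluorophenyl gives a lower number again. Since compound 4 also leaves the 2-fluorophenyl behind, a drop toward the level of compound 1 is expected, roughly a 6.5-fold lower number from compound 2 to compound 4 (0.81 log units; beyond the scatter). Compound 4 is therefore estimated at 5000 nM, with a likely range from 1500 nM to 16000 nM.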

Compound 4, half-maximal inhibitory concentration: 1380 nM
Beside the measured number, compound 4's estimate is 3.6-fold (0.56 log units) above it; the whole stated range lies above it.
By their numbers in this assay, from the lowest: compound 4; then compound 1; then compound 3; then compound 2.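

The 3,4-dichlorophenyl group on the carbonyl carbon gives compound 4 the lowest number of the four in this assay, with a 24-fold lower number from compound 2 to compound 4 (1.37 log units; beyond the scatter) and a 9.6-fold lower number from compound 3 to compound 4 (0.98 log units; beyond the scatter) and a 2.9-fold lower number from compound 1 to compound 4 (0.47 log units; beyond the scatter). Compound 1 therefore did not mark the lowest number reachable by changing this aromatic ring, and the ring's substituents can shift the result widely while the core stays the same. Nothing measured here explains this gain. The compounds shown leave open whether both chlorines are needed, which a 3-chlorophenyl or 4-chlorophenyl group would help settle. On these data alone, how a trifluoromethyl group or a carboxylic acid on this ring would read also remains open.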